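This account rests on a few compounds, and the source may have more. Where it says the series, first, only, none or still open, it means among the compounds named here.

Working notes on the series. Compound 1 `Cc1cc(Nc2cc(-c3ccccc3)[nH]n2)n2nc(SCc3cccc(Br)c3)nc2n1` carries a (3-bromobenzyl)sulfanyl group on the shared core. In an ADME assay on GES1 cells (Homo sapiens) for inhibition, read by MTT assay, with a stated time of 72 h (on this read-out lower numbers stand for stronger inhibition and higher numbers for weaker inhibition), compound 1 gives > 50000 nM, which is a limit of the assay and not a number. Compound 1 therefore sits at the limit of > 50000 nM in this assay, at which 2 of the 3 values shown sit. Compound 2 `Cc1cc(Nc2cc(-c3ccc(F)cc3)[nH]n2)n2nc(SCc3ccc(Br)cc3)nc2n1` gives 34200 nM in this assay. Compound 3 `COc1ccc(Cn2ccc(Nc3cc(C)nc4nc(SCc5ccc(Br)cc5)nn34)n2)cc1` gives > 50000 nM in this assay, a limit and not a number. Among the measured compounds shown here, no two measured compounds differ in one place, so no measured step is available. Compound 4 `Cc1cc(Nc2cc(-c3ccccc3)[nH]n2)n2nc(SCC3CC3)nc2n1` differs from compound 1 by cyclopropyl in place of 3-bromophenyl on a saturated chain carbon bound to a sulfur. With compound 1 at a limit, the expected step that the limit leaves unreadable from compound 1 to compound 4 is none beyond the scatter in either direction. Compound 4 is expected at 60000 nM, with a range from 20000 nM to 200000 nM.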

Compound 4, half-maximal inhibitory concentration: > 50000 nM
Compound 4 was reported as a limit (the forecaster's own chance of this, stated with the estimate: 70%); the middle value does not contradict the limit.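

Among the compounds shown here, no step from compound 1 to compound 4 can be read: each value is a limit and not a number. The compounds shown leave open whether cyclopropyl in place of 3-bromophenyl changes the inhibition at all.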